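One methyl added to the core of compound 1

The source may report more compounds than this note shows. Statements on the series, on what has been measured and on what is new or still open speak of the compounds shown alone.

In an ADME assay on MT4 cells (Homo sapiens) for cytotoxicity, read by MTT assay, with a stated time of 96 h (on this read-out lower numbers stand for higher toxicity in this test and higher numbers for lower toxicity in this test), compound 1 `CN(CC(=O)O)Cc1c(O)ccc2ccc(=O)oc12` reads > 100000 nM as a limit and not as a number. Compound 2 `Cc1cc(=O)oc2c(CN3CCc4ccccc4C3)c(O)ccc12` likewise reads > 100000 nM as a limit. Compound 1 therefore stands at the limit of > 100000 nM in this assay, at which 2 of the 3 values shown sit, and has no exact position on the scale. Compound 3 `COc1ccc2[nH]cc(Cc3c(OC(C)=O)ccc4c(C)cc(=O)oc34)c2c1` gives 72000 nM as an actual number.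

Compound 4 `Cc1cc(=O)oc2c(CN(C)CC(=O)O)c(O)ccc12` has not yet been measured. It differs from compound 1 in one place, (methyl in place of hydrogen on an aromatic carbon), with methyl in place of hydrogen on an aromatic carbon. Going by the values given here, no measured pair isolates this change, so its size can only be expected. Compound 2 carries the same methyl and reads > 100000 nM as a limit, so no step beyond the scatter is expected in this assay for this change. The expected step of a number no higher from compound 1 to compound 4 (the limit leaves the size open) is an estimate only, and a limit is again the likely report. For compound 4 the estimated value is 100000 nM, within an expected range from 50000 nM to 200000 nM.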

Compound 4, half-maximal cytotoxic concentration: > 100000 nM
Compound 4 gave a limit, no number; the forecaster's own chance of this, stated with the estimate: 80%; the middle value lies on the limit itself.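

In this assay compound 1 and compound 4 both stand only as limits, so no step can be read for methyl in place of hydrogen on an aromatic carbon. The compounds shown leave open whether this methyl shifts the read-out at all, with neither compound placed on the scale.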